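Swapping the benzyl substituent: cyano for methyl

This account rests on a few compounds, and the source may have more. Where it says the series, first, only, none or still open, it means among the compounds named here.

Within the data shown here, compound 2 `Cc1cccc(COc2cc(O)c3c(=O)c(O)c(-c4ccccc4)oc3c2)c1` gives 35000 nM in an ADME assay on Huh-5-2 cells (Homo sapiens) for cytotoxicity, read by WST assay, with a stated time of 3 days (on this read-out lower numbers stand for higher toxicity in this test and higher numbers for lower toxicity in this test), the higher of the two numbers so far; its neighbour, compound 1 `O=c1c(O)c(-c2ccccc2)oc2cc(OCc3ccccc3[N+](=O)[O-])cc(O)c12`, gives 32000 nM. The step of a 1.1-fold higher number from compound 1 to compound 2 (0.04 log units; within the scatter) shows that changing the group on the benzyl carbon left the read-out within the scatter. Compound 3 `N#Cc1ccc(COc2cc(O)c3c(=O)c(O)c(-c4ccccc4)oc3c2)cc1` carries the change (4-cyanophenyl in place of 3-methylphenyl on a saturated chain carbon bound to an oxygen on an aromatic ring). Among the measured compounds shown here, since the only comparable step stayed within the scatter, the expected step of a 1.0-fold lower number from compound 2 to compound 3 (0.01 log units; within the scatter) is none beyond the scatter. Compound 3 is therefore estimated at 34000 nM, with a range from 15000 nM to 75000 nM.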

Compound 3, half-maximal cytotoxic concentration: 94000 nM
The estimate for compound 3 lay 2.8-fold (0.44 log units) below the measured number; the measured number lies above the stated range.
By their numbers in this assay, from the lowest: compounds 1 and 2 (each within the scatter of the next); then compound 3.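

In this assay, this position proves able to move the read-out: there is a 2.7-fold higher number from compound 2 to compound 3 (0.43 log units; beyond the scatter) and a 2.9-fold higher number from compound 1 to compound 3 (0.47 log units; beyond the scatter), whereas the earlier step between compound 1 and compound 2 stayed within the scatter. Among these three benzyl groups, 4-cyanophenyl therefore gives the lowest toxicity in this test, though the step is modest. No measurement here explains the shift. Compound 3 differs from compound 2 in both the group and its place on the ring, so the effect of the nitrile alone remains unclear. From the compounds shown here alone, how a 3-cyanophenyl group, an amine or a carboxylic acid would read also remains open.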